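A few compounds are considered here, and "the series" means these few. Any claim that something is new, unique, unknown or untested is made for them only; others in the source may bear on it.

Three compounds sharing one core have been run in a functional assay on Caco-2 cells (Homo sapiens) for inhibition, read by MTT assay, with a stated time of 72 h; a lower number here means a stronger inhibitor, a higher number a weaker inhibitor. Compound 1 `CCCNC(=C\C(=O)/C=C/c1ccc(O)c(OC)c1)/C=C/c1ccc(O)c(OC)c1` returns only a limit of the assay, > 25000 nM. Compound 3 `C=CCNC(=C\C(=O)/C=C/c1ccc(O)c(OC)c1)/C=C/c1ccc(O)c(OC)c1` returns a limit as well, > 25000 nM. The step that the two limits leave unreadable from compound 1 to compound 3 is thus unreadable in size and direction, since both of its values sit at the limit of > 25000 nM in this assay, at which 3 of the 3 values shown sit. Compound 2 `CCC(C)NC(=C\C(=O)/C=C/c1ccc(OC(C)=O)c(OC)c1)/C=C/c1ccc(OC(C)=O)c(OC)c1` is the third member, and in this assay compound 2 gives > 25000 nM, again a limit rather than a number, so for compound 2 only a limit is known, as for the two further values shown. The unmeasured compound 4 `COc1cc(/C=C/C(=O)/C=C(/C=C/c2ccc(OC(C)=O)c(OC)c2)NCC(C)C)ccc1OC(C)=O` differs from compound 2 in a single place: isobutyl in place of sec-butyl on an amine nitrogen. For the measured compounds named here, no measured step bears directly on this change, and the one step that exists between measured compounds, a step that the two limits leave unreadable from compound 1 to compound 3, cannot be read. With every value at the limit, no direction can be taken from the data, and compound 4 is expected to return a limit too, the step that the limit leaves unreadable from compound 2 to compound 4 being expected to stay within the scatter. Compound 4 is accordingly estimated at 40000 nM, in a range from 12000 nM to 150000 nM.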

Compound 4, half-maximal inhibitory concentration: > 25000 nM
Compound 4 ended at the assay's limit; the forecaster's own chance of this, stated with the estimate: 80%; the middle value lies beyond the limit too.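

Compound 2 and compound 4 both return only a limit, so no new step can be read between them: the limit of > 25000 nM in this assay, at which 4 of the 4 values shown sit.

The compounds shown leave open whether any group on the amine nitrogen changes the result in this assay, and none of them gives a number there.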